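A few compounds are considered here, and "the series" means these few. Any claim that something is new, unique, unknown or untested is made for them only; others in the source may bear on it.

Series notes. In a functional assay on HeLa cells (Homo sapiens) for antiproliferative activity, with a stated time of 24 h (a higher number here means a weaker inhibitor, a lower number a stronger inhibitor), compound 1 `NC(=O)c1c(NC(=O)c2ccccc2Cl)sc2c1CCN(Cc1ccccc1Cl)C2` gives 27500 nM. Compound 2 `NC(=O)c1c(NC(=O)c2ccccc2Cl)sc2c1CCN(Cc1ccccc1F)C2` returns a limit of this assay, > 50000 nM, and no number. The change between them, (fluoro in place of chloro on an aromatic carbon), gives an at least 1.8-fold higher number from compound 1 to compound 2 (0.25 log units; that floor lies within the scatter); the step is known only as a floor because of the limit of > 50000 nM in this assay, at which 1 of the 3 values shown sits. Compound 3 `NC(=O)c1c(NC(=O)c2ccccc2Cl)sc2c1CCN(C(=S)Nc1cc(C(F)(F)F)cc(C(F)(F)F)c1)C2` gives 48900 nM in this assay; how its core differs from the core of compound 1 is not broken down here. Compound 4 `NC(=O)c1c(NC(=O)c2ccccc2F)sc2c1CCN(C(=S)Nc1cc(C(F)(F)F)cc(C(F)(F)F)c1)C2` carries the same change relative to compound 3, (fluoro in place of chloro on an aromatic carbon), the place reading the same word for word, though cut one bond further out it reads 2-chlorobenzyl in compound 1 and (2-chlorophenyl)carbonyl in compound 3. For the measured compounds named here, the step of an at least 1.8-fold higher number from compound 1 to compound 2 (0.25 log units; that floor lies within the scatter) is the only guide. On that basis a step of a 1.7-fold higher number from compound 3 to compound 4 (0.24 log units; within the scatter) is expected in this assay. Compound 4 is estimated at 85000 nM, most probably returned as a limit.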

Compound 4, half-maximal inhibitory concentration: 28000 nM
Compound 4: middle estimate off by 3.0-fold (0.48 log units), on the high side; the whole stated range lies above it.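

In this assay, fluoro in place of chloro on the (2-chlorophenyl)carbonyl gives a 1.7-fold lower number from compound 3 to compound 4 (0.24 log units; within the scatter). The change does not carry over as a single step between the two cores: the same change on two cores in this assay, an at least 1.8-fold higher number (0.25 log units; that floor lies within the scatter) from compound 1 to compound 2 and a 1.7-fold lower number (0.24 log units; within the scatter) from compound 3 to compound 4, at least 3.1-fold (0.50 log units) apart, beyond the scatter of two such steps. It remains unshown whether this gap follows from the place of the change, 2-chlorobenzyl in compound 1 against (2-chlorophenyl)carbonyl in compound 3, or from the rest of the core, and the earlier step has no full size: the limit of > 50000 nM in this assay, at which 1 of the 4 values shown sits.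

Open, going by these compounds, is how the same change on the (2-chlorophenyl)carbonyl reads when the 2-chlorobenzyl of compound 1 is kept. Also open, on these data alone, is how a methoxy group or an amine at this place on the aromatic ring reads in this assay.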